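A few compounds are considered here, and "the series" means these few. Any claim that something is new, unique, unknown or untested is made for them only; others in the source may bear on it.

Compound 1, `COc1cc(-c2cc(/C=C/C(=O)c3ccc(N)cc3)[nH]n2)cc(OC)c1OC`, in a functional assay on SNB-19 cells (Homo sapiens) for cytotoxicity, read by sulforhodamine B assay, with a stated time of 48 h, tested at 100 uM (on this read-out higher numbers stand for a weaker effect at the one concentration tested and lower numbers for a stronger effect), gives -94%.
Compound 2, `COc1ccc(-c2cc(/C=C/C(=O)c3ccc(N)cc3)[nH]n2)cc1OC`, in this assay gives -91%.
Compound 3, `COc1cc(C(=O)/C=C/c2cc(-c3cc(OC)c(OC)c(OC)c3)n[nH]2)cc(OC)c1OC`, in this assay gives -98%.

Compound 2 differs from compound 1 in one place: hydrogen in place of methoxy on an aromatic carbon. That change made a number 3 percentage points higher from compound 1 to compound 2 (within the scatter), so the read-out was hardly moved by taking this methoxy away. How the core of compound 3 differs from the core of compound 1 is not broken down here; the three measured values all lie within the scatter of one another, so none of them can be set apart from the rest.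

Compound 4, `COc1ccc(-c2cc(/C=C/C(=O)c3cc(OC)c(OC)c(OC)c3)[nH]n2)cc1OC`, has not been measured. It differs from compound 3 by hydrogen in place of methoxy on an aromatic carbon, the same change as between compound 1 and compound 2, at a place described in the same words. On the strength of a number 3 percentage points higher from compound 1 to compound 2 (within the scatter), a step of the same kind is expected here: a number 3 percentage points higher from compound 3 to compound 4 (within the scatter). Because compound 3 gives -98%, compound 4 is expected to give about -95% in this assay, most likely somewhere between -100% and -84%.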

Compound 4, a percentage reported as activity, at one concentration (the size of the read-out at that concentration, not a potency): -77%
Estimate against measurement, compound 4: 18 percentage points below; the whole stated range lies below it.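

In this assay, removing the methoxy on the core of compound 3 gave a number 21 percentage points higher from compound 3 to compound 4 (beyond the scatter), so this change does not have to be small in this series. Set beside the earlier step, the same change did not keep its size when carried from one core to the other: the same change on two cores in this assay, a number 3 percentage points higher (within the scatter) from compound 1 to compound 2 and a number 21 percentage points higher (beyond the scatter) from compound 3 to compound 4, 18 percentage points apart, beyond the scatter of two such steps This shows that a step measured on one core was a poor guide to the step on the other, but two pairs cannot show which feature of the cores matters, why the steps differ, or what size the step would have on a third core.

The compounds shown carry only methoxy or hydrogen at the changed place, so it remains open how a hydroxyl group, a fluorine atom or a longer chain such as ethoxy would read out there. As far as these compounds go, it also remains open whether the gap between the two steps would persist at concentrations other than the single one tested.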